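This account rests on a few compounds, and the source may have more. Where it says the series, first, only, none or still open, it means among the compounds named here.

Compound 1 `CC1CC/C(=N\Nc2ccccc2F)c2ncc(C(=O)O)c(=O)n21`: in a functional assay on the whole organism for inhibition, with Rattus norvegicus as the target (a higher number here means that more compound is needed for the effect, a lower number that less compound is needed), compound 1 gives > 1000 umol/kg, which is a limit of the assay and not a number.
Compound 2 `CC1CC/C(=N\Nc2cccc(Cl)c2)c2ncc(C(=O)O)c(=O)n21`: in this assay compound 2 gives > 100 umol/kg, again only a limit.
Compound 3 `CC1CC/C(=N\Nc2ccccc2Br)c2ncc(C(=O)O)c(=O)n21`: in this assay compound 3 gives > 320 umol/kg, also a limit.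

Compound 3 therefore stands at a limit, and the two other values shown are limits too. Compound 4 `CC1CC/C(=N\Nc2ccc(I)cc2)c2ncc(C(=O)O)c(=O)n21` differs from compound 3 by 4-iodophenyl in place of 2-bromophenyl on an amine nitrogen. The steps a step that the two limits leave unreadable from compound 1 to compound 2, a step that the two limits leave unreadable from compound 1 to compound 3 and a step that the two limits leave unreadable from compound 2 to compound 3 all touch this series, yet none can be read because of the limit of > 100 umol/kg in this assay, at which 1 of the 3 values shown sits, the limit of > 1000 umol/kg in this assay, at which 1 of the 3 values shown sits, and the limit of > 320 umol/kg in this assay, at which 1 of the 3 values shown sits, show both ends of every step resting at a limit. No direction or size beyond the scatter can be expected from them. Compound 4 is estimated at 500 umol/kg, within 100 umol/kg to 3000 umol/kg, most likely again reported only as a limit. The expected step is a step that the limit leaves unreadable from compound 3 to compound 4.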

Compound 4, dose for 50% inhibition: > 1000 umol/kg
Compound 4 ended at the assay's limit; the forecaster's own chance of this, stated with the estimate: 80%; middle value at least 2.0-fold (0.30 log units) away from the limit.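

Compound 4 also rests at a limit of the assay, and its steps from compound 1, compound 2 and compound 3 cannot be read. The compounds shown leave open how these four substituted phenyl groups rank in this assay, and what dose of any compound gives the effect.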